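Methyl in place of fluoro: an oral exposure estimate

The source may hold more compounds than are shown below. What is called first, only, known or untested is meant among the compounds shown, and "the series" means these compounds.

compound 1 `Cc1cc(C(=O)O)cc(C)c1NC(=O)c1nc(-c2cccc(CO)c2)ccc1C(F)(F)F` gives 243 ng.h/mL
compound 2 `Cc1ccc(C(=O)O)c(C)c1NC(=O)c1nc(-c2cccc(CO)c2)ccc1C(F)(F)F` gives 1540 ng.h/mL
compound 3 `Cc1ccc(C(=O)O)c(C)c1NC(=O)c1cc(-c2cccc(CO)c2)ccc1F` gives 994 ng.h/mL

In an ADME assay on the whole organism for pharmacokinetics, with Rattus norvegicus as the target, at a dose of 5 mg/kg by the oral route (a higher number here means more compound in the circulation at the dose given, a lower number less compound in the circulation), compound 3 gives 994 ng.h/mL and lies within the scatter of compound 2 at 1540 ng.h/mL on this measure. Compound 1 gives 243 ng.h/mL on the same measure. The gap between compound 3 and compound 1 lies beyond the scatter, with compound 3 the higher of the two.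

Compound 4 `Cc1ccc(-c2cccc(CO)c2)cc1C(=O)Nc1c(C)ccc(C(=O)O)c1C` has not yet been measured. It differs from compound 3 by methyl in place of fluoro on an aromatic carbon, ortho to a large group and para to a 3-(hydroxymethyl)phenyl group (methyl in place of fluoro on an aromatic carbon). Among the measured compounds shown here, no two measured compounds differ in one place only, so the data give no direct size for this change.

The expectation in this assay is therefore for no step beyond the scatter, in either direction. For the measured compounds named here, it rests on compound 3 at 994 ng.h/mL as the only measured compound that differs from compound 4 by this single change. The expected change is a 1.1-fold lower number from compound 3 to compound 4 (0.04 log units; within the scatter) and this estimated step stays within the scatter. For compound 4 the estimated value is 900 ng.h/mL within an expected range from 300 ng.h/mL to 2700 ng.h/mL on this measure.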

Compound 4, area under the concentration-time curve: 375 ng.h/mL
Beside the measured number, compound 4's estimate is 2.4-fold (0.38 log units) above it, within the range that was stated.
By their numbers in this assay, from the lowest: compounds 1 and 4 (each within the scatter of the next); then compounds 3 and 2 (each within the scatter of the next).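

In this assay, methyl in place of fluoro on this aromatic carbon, ortho to a large group and para to a 3-(hydroxymethyl)phenyl group, gives a 2.7-fold lower number from compound 3 to compound 4 (0.42 log units; beyond the scatter), so the change is not neutral here. The step is modest, but it lies beyond the scatter even though one heavy atom simply replaces another and the exchange adds no ring, no hydrogen-bond donor or acceptor and no net charge. Nothing available explains this step or ties it to any property of either group.

The compounds shown leave open how other groups on this carbon, such as hydrogen, chloro, methoxy or a nitrile, would read in this assay, and so whether fluoro and methyl mark the ends of a wider spread or lie close together within one. Among the compounds shown here, they also leave open whether the same exchange would give a step of similar size elsewhere, since this single pair offers only one position on one core, at one dose and by one route.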